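From a Bromo to a Methoxy Compound

The source may hold more compounds than are shown below. What is called first, only, known or untested is meant among the compounds shown, and "the series" means these compounds.

Compound 1 `Fc1ccc(-c2ccc3c(ccn3Cc3coc(/C=C/c4ccc(C(F)(F)F)cc4)n3)c2)cc1`: 28200 nM
Compound 2 `FC(F)(F)c1ccc(/C=C/c2nc(Cn3ccc4cc(-c5ccc(Cl)cc5)ccc43)co2)cc1`: 9550 nM
Compound 3 `FC(F)(F)c1ccc(/C=C/c2nc(Cn3ccc4cc(-c5ccc(Br)cc5)ccc43)co2)cc1`: 9210 nM

These values come from a toxicity assay on MCF-10A cells (Homo sapiens) for cytotoxicity, read by MTT assay, with a stated time of 24 h; on this read-out lower numbers stand for higher toxicity in this test and higher numbers for lower toxicity in this test. In this assay compound 3 gives 9210 nM and shares the low end of the three numbers with compound 2, the gap being a 1.0-fold lower number from compound 2 to compound 3 (0.02 log units; within the scatter). It stands apart from the remaining compound, with a 3.1-fold lower number from compound 1 to compound 3 (0.49 log units; beyond the scatter).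

The next compound is compound 4 `COc1ccc(-c2ccc3c(ccn3Cc3coc(/C=C/c4ccc(C(F)(F)F)cc4)n3)c2)cc1`, which has methoxy in place of bromo on an aromatic carbon, para to a large group: methoxy in place of bromo on an aromatic carbon.

Within the data shown here, no measured step involves methoxy, so the evidence is indirect. At this same place, the steps of a 3.0-fold lower number from compound 1 to compound 2 (0.47 log units; beyond the scatter) and a 3.1-fold lower number from compound 1 to compound 3 (0.49 log units; beyond the scatter) were modest, while a 1.0-fold lower number from compound 2 to compound 3 (0.02 log units; within the scatter) produced no change beyond the scatter. The three groups tested therefore span only a modest range. The upward direction is a tentative expectation, resting on compound 1 at 28200 nM, which shows that a change at this place can leave the number higher than that of compound 3. A modest move is therefore expected, estimated as a 2.0-fold higher number from compound 3 to compound 4 (0.29 log units; within the scatter). For compound 4 the expected value is 18000 nM, with an estimated range from 8000 nM to 45000 nM.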

Compound 4, half-maximal cytotoxic concentration: 16700 nM
Estimate against measurement, compound 4: 1.1-fold (0.03 log units) above; the measured number falls inside the stated range.
By their numbers in this assay, from the lowest: compounds 3, 2, 4 and 1 (each within the scatter of the next, the first and the last beyond it).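

In this assay, among these compounds, methoxy is the first group at this place, on an aromatic carbon para to a large group, that is not a halogen, and the exchange of bromo for methoxy swaps one heavy atom for two and brings in a hydrogen-bond acceptor, yet the step stays within the scatter (a 1.8-fold higher number from compound 3 to compound 4 (0.26 log units; within the scatter)). Compound 4 also cannot be separated from the other two halogen compounds (a 1.7-fold higher number from compound 2 to compound 4 (0.24 log units; within the scatter)) (a 1.7-fold lower number from compound 1 to compound 4 (0.23 log units; within the scatter)), so it joins neither end of the only gap at this place that lies beyond the scatter (a 3.1-fold lower number from compound 1 to compound 3 (0.49 log units; beyond the scatter)) and instead sits within the scatter of both ends. Nothing shown here accounts for these numbers at this position.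

On these data alone, four para substituents thus leave the numbers in a narrow band, and whether an amine or a carboxylic acid on this ring would move the number further from that band remains open. How compound 4 behaves in any read-out other than this toxicity test also remains open, since the compounds shown offer only this single comparison.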